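The source may hold more compounds than are shown below. What is called first, only, known or untested is meant among the compounds shown, and "the series" means these compounds.

Compound 1 `COc1ccc(/C=C/C(=O)c2ccncc2)cc1OC`: 420 nM
Compound 2 `CCOc1cc(/C=C/C(=O)c2ccncc2)cc(OC)c1OC`: 63 nM
Compound 3 `CCOc1c(OC)cc(/C=C/C(=O)c2ccncc2)cc1OC`: 280 nM

All three were tested in an assay on HEK293 cells for inhibition of cytochrome P450 1A1 (Homo sapiens), read by fluorescence, with stated times of 30 min and 60 min; a higher number here means a weaker inhibitor, a lower number a stronger inhibitor. Compound 2 and compound 1 differ in one place, (hydrogen in place of ethoxy on an aromatic carbon), and that step gave a 6.7-fold higher number from compound 2 to compound 1 (0.82 log units; beyond the scatter). Compound 3 and compound 2 are built from the same atoms joined differently; the difference between the two cores is not broken down here. Compound 3 and compound 1 lie within the usual scatter of each other.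

Compound 4 `COc1cc(/C=C/C(=O)c2ccncc2)cc(OC)c1` is not yet measured and differs from compound 3 by hydrogen in place of ethoxy on an aromatic carbon. This is the same kind of change as from compound 2 to compound 1, but the place is not the same: here the ethoxy sits ortho to two methoxy groups and para to a large group, whereas in compound 2 it sits ortho to a methoxy group, meta to a large group and meta to a methoxy group. Since the earlier removal gave a 6.7-fold higher number from compound 2 to compound 1 (0.82 log units; beyond the scatter), the step from compound 3 to compound 4 in this assay is expected to be a 3.9-fold higher number from compound 3 to compound 4 (0.59 log units; beyond the scatter), somewhat smaller given the different surroundings. Compound 4 is estimated at 1100 nM, likely between 400 nM and 3500 nM.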

Compound 4, half-maximal inhibitory concentration: 220 nM
Estimate against measurement, compound 4: 5.0-fold (0.70 log units) above; measured number outside the range, below it.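

In this assay, putting hydrogen in place of ethoxy gave a 1.3-fold lower number from compound 3 to compound 4 (0.10 log units; within the scatter), so on this core the change made no clear difference. The same change therefore did not carry over from one core to the other: the same change on two cores in this assay, a 6.7-fold higher number (0.82 log units; beyond the scatter) from compound 2 to compound 1 and a 1.3-fold lower number (0.10 log units; within the scatter) from compound 3 to compound 4, 8.5-fold (0.93 log units) apart, beyond the scatter of two such steps. These two pairs show that the result of this change cannot be assumed to transfer within the series, but they do not show whether the place of the ethoxy or some other feature of each core accounts for the gap.

On these data alone, it remains open whether a longer chain, such as propoxy, would follow the ethoxy result on each core. The same question stands for an amine on that aromatic carbon.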